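Trimming the Ketone Aryl Ring in a Hydroxamate Series

The source may hold more compounds than are shown below. What is called first, only, known or untested is meant among the compounds shown, and "the series" means these compounds.

Compound 1 `COc1ccc(C(=O)c2ccc3c(ccn3S(=O)(=O)c3cccc(/C=C/C(=O)NO)c3)c2)cc1OC` is examined in an assay on isolated protein for inhibition of histone deacetylase 8 (Homo sapiens) (a higher number here means a weaker inhibitor, a lower number a stronger inhibitor), where compound 1 gives 1420 nM. Among the two compounds with a number in this assay, compound 1 has the highest. Its nearest neighbour, compound 2 `COc1ccc(C(=O)c2ccc3c(ccn3Cc3ccc(C(=O)NO)cc3)c2)cc1`, gives 646 nM in this assay, a lower number whose gap to compound 1 lies beyond the usual scatter. Compound 3 `COc1cc(C(=O)c2ccc3c(ccn3Cc3ccc(C(=O)NO)cc3)c2)cc(OC)c1OC` gives "not determined" (no result reported) in this assay, that is, no result reported. The next compound, compound 4 `Cc1ccc(C(=O)c2ccc3c(ccn3S(=O)(=O)c3cccc(/C=C/C(=O)NO)c3)c2)cc1`, differs from compound 1 in one place: 4-methylphenyl in place of 3,4-dimethoxyphenyl on a carbonyl carbon. Among the compounds with values here, no step between two measured compounds mirrors this change, so the expectation rests on compound 1 alone. The step expected in this assay is a 1.4-fold higher number from compound 1 to compound 4 (0.15 log units; within the scatter), a small shift toward a weaker inhibitor, at the edge of the scatter. Compound 4 is therefore expected to give about 2000 nM in this assay, in a range from 700 nM to 6000 nM.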

Compound 4, half-maximal inhibitory concentration: 4480 nM
The estimate for compound 4 lay 2.2-fold (0.35 log units) below the measured number; the range from low to high includes it.
By their numbers in this assay, from the lowest: compound 2; then compound 1; then compound 4.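

In this assay, the ketone aryl position proves sensitive to this exchange, with a 3.2-fold higher number from compound 1 to compound 4 (0.50 log units; beyond the scatter), a shift toward a weaker inhibitor. Trading the 3,4-dimethoxyphenyl for 4-methylphenyl on the carbonyl carbon replaces an aryl group bearing oxygen with one of carbon only, and this single step cannot separate the loss of either methoxy group from the gain of the methyl. Nothing available accounts for the shift.

Going by these compounds, whether a 4-hydroxyphenyl or 4-aminophenyl on the carbonyl carbon would keep the number near that of compound 1 remains open. So does the effect of a lone methoxy group on this same core.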